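This account rests on a few compounds, and the source may have more. Where it says the series, first, only, none or still open, it means among the compounds named here.

The study turns on a shared core carrying a cyano group and two amino groups, with a pair of halogens on the carbon ring. Compound 1 `N#Cc1c(F)c(Cl)c2nc(N)nc(N)c2c1F` holds a chloro substituent there, and in a functional assay on HepG2 cells (Homo sapiens) for cytotoxicity, read by MTT assay (on this read-out lower numbers stand for stronger inhibition and higher numbers for weaker inhibition), compound 1 gives 4.8 ug/mL. Compound 2 `N#Cc1c(F)c(F)c2nc(N)nc(N)c2c1F` replaces that substituent; in this assay compound 2 gives 5 ug/mL. The change between them, (fluoro in place of chloro on an aromatic carbon), produced a step of a 1.0-fold higher number from compound 1 to compound 2 (0.02 log units; within the scatter), so the two numbers are read as the same.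

Compound 3 `N#Cc1c(NCc2ccccc2)c(Cl)c2nc(N)nc(N)c2c1NCc1ccccc1` has a core unlike that of compound 1, and the difference between the two cores is not broken down here. In this assay compound 3 gives 19.2 ug/mL, the highest of the three numbers and beyond the scatter from both compound 1 and compound 2.

Compound 4 `N#Cc1c(NCc2ccccc2)c(F)c2nc(N)nc(N)c2c1NCc1ccccc1` has not yet been tested. It differs from compound 3 by fluoro in place of chloro on an aromatic carbon. Among the compounds with values here, this is the same kind of change as the one from compound 1 to compound 2, but not the same: in compound 1 the changed carbon is ortho to a fluoro group and para to a fluoro group, whereas in compound 3 it is ortho to a benzylamino group and para to a benzylamino group. Resting on the earlier step of a 1.0-fold higher number from compound 1 to compound 2 (0.02 log units; within the scatter), the step expected here is a 1.0-fold lower number from compound 3 to compound 4 (0.00 log units; within the scatter). Compound 4 is therefore expected to give about 19 ug/mL in this assay, somewhere between 10 ug/mL and 38 ug/mL.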

Compound 4, half-maximal inhibitory concentration: 13.4 ug/mL
Beside the measured number, compound 4's estimate is 1.4-fold (0.15 log units) above it; the measured number falls inside the stated range.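

In this assay, putting fluoro in place of chloro on the aromatic carbon gave a 1.4-fold lower number from compound 3 to compound 4 (0.16 log units; within the scatter), so the two numbers are read as the same. Set beside the earlier step, the change behaves alike on the core of compound 1, where the neighbouring substituents are fluoro groups, and on the core of compound 3, which carries two benzylamino groups: the same change on two cores in this assay, a 1.0-fold higher number (0.02 log units; within the scatter) from compound 1 to compound 2 and a 1.4-fold lower number (0.16 log units; within the scatter) from compound 3 to compound 4, 1.5-fold (0.17 log units) apart, within the scatter of two such steps. This shows that, for these two pairs in this single cytotoxicity read-out, the exchange of one halogen for the other leaves the number within the scatter on both cores, but it does not show that the same would hold on any other core, and it says nothing about why the two steps agree.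

The compounds shown leave open what other groups would do at the same aromatic carbon, such as a bromo, a methoxy or a simple amine, since only chloro and fluoro appear there. They also leave open how the number would respond if the benzylamino groups gave way to a morpholine, a longer alkylamine chain or a substituted benzylamine, on a core with either halogen.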